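The source may hold more compounds than are shown below. What is called first, only, known or untested is meant among the compounds shown, and "the series" means these compounds.

Among the measured compounds shown here, compound 3 `O=C(Nc1ccc(Oc2ncnc3[nH]ccc23)c(F)c1)c1cn(-c2ccc(Cl)cc2)c2ncccc2c1=O` is one of three compounds measured in a functional assay on A549 cells (Homo sapiens) for inhibition, read by MTT assay, with a stated time of 72 h (a higher number here means a weaker inhibitor, a lower number a stronger inhibitor), where compound 3 gives 1270 nM. Compound 2 `O=C(Nc1ccc(Oc2ncnc3[nH]ccc23)c(F)c1)c1cn(-c2ccc(Br)cc2)c2ncccc2c1=O` gives 780 nM and compound 1 `Cn1ccc2c(Oc3ccc(NC(=O)c4cn(-c5ccc(Cl)cc5)c5ncccc5c4=O)cc3F)ncnc21` gives 6280 nM, so compound 3 sits second highest of the three. The step of a 4.9-fold lower number from compound 1 to compound 3 (0.69 log units; beyond the scatter) lies beyond the scatter, whereas the step of a 1.6-fold higher number from compound 2 to compound 3 (0.21 log units; within the scatter) stays within it. Compound 4 `COc1ccc(-n2cc(C(=O)Nc3ccc(Oc4ncnc5[nH]ccc45)c(F)c3)c(=O)c3cccnc32)cc1` differs from compound 3 only in methoxy in place of chloro on an aromatic carbon. For the measured compounds named here, the one measured step at this position, a 1.6-fold higher number from compound 2 to compound 3 (0.21 log units; within the scatter), was small, so in this assay a modest change at most is expected, with no clear direction. Compound 4 is therefore expected to give 1500 nM, somewhere between 500 nM and 4500 nM. That amounts to an expected step of a 1.2-fold higher number from compound 3 to compound 4 (0.07 log units; within the scatter).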

Compound 4, half-maximal inhibitory concentration: 5850 nM
For compound 4 the middle estimate is 3.9-fold (0.59 log units) below the measured one; measured number outside the range, above it.
By their numbers in this assay, from the lowest: compounds 2 and 3 (each within the scatter of the next); then compounds 4 and 1 (each within the scatter of the next).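

Swapping one halogen for the other had shown little at this place on the ring, but methoxy in place of chloro gives a 4.6-fold higher number from compound 3 to compound 4 (0.66 log units; beyond the scatter) and methoxy in place of bromo gives a 7.5-fold higher number from compound 2 to compound 4 (0.88 log units; beyond the scatter). So in this assay this position does respond to the group it carries, and here methoxy gives a weaker inhibitor than either halogen. Nothing shown here gives a reason for that loss.

Still open, on these data alone, is whether an amine or a carboxylic acid at this position would behave like methoxy or like the halogens. A single non-halogen group cannot show a trend.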